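Cyano for pyrrolidinyl on the shared core: cytotoxicity outlook

The compounds below may be only part of what the source reports. "The series", "measured", "known", "first", "only" and "open" are said of these compounds alone.

Values in an ADME assay on HEL cells (Homo sapiens) for cytotoxicity, with a stated time of 3 days; a higher number here means that more compound is tolerated, a lower number that less compound is tolerated:
compound 1 `Cc1cc(-c2ccoc2)cn2c(CSCCc3ccccc3)cnc12` gives 12 ug/mL.
compound 2 `Cc1cc(N2CCCC2)c2ncc(CSCCc3ccccc3)n2c1` gives > 100 ug/mL, a limit of the assay.
compound 3 `Cc1cc(N2CCCC2)c2ncc(CSCc3ccccc3)n2c1` gives 52 ug/mL.

Compound 2 thus stands only at the limit of > 100 ug/mL in this assay, at which 1 of the 3 values shown sits, with no number of its own. Compound 4 `Cc1cc(C#N)c2ncc(CSCCc3ccccc3)n2c1` differs from compound 2 by cyano in place of pyrrolidin-1-yl on an aromatic carbon. For the measured compounds named here, the single measured step, an at least 1.9-fold lower number from compound 2 to compound 3 (0.28 log units; that floor lies within the scatter), concerns the chain on the sulfur and not the group exchanged here, so no measured step bears on this change. The expectation for compound 4 therefore rests on compound 2 alone, and a number no higher from compound 2 to compound 4 (the limit leaves the size open) is expected to stay within the scatter. Compound 4 is estimated at 100 ug/mL in this assay, between 30 ug/mL and 300 ug/mL.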

Compound 4, half-maximal cytotoxic concentration: > 100 ug/mL
Compound 4 was reported as a limit; the forecaster's own chance of this, stated with the estimate: 50%; the middle value lies on the limit itself.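

In this assay compound 4 gives > 100 ug/mL, a limit of the assay; compound 2 also rests on a limit, so no step between them can be read: the limit of > 100 ug/mL in this assay, at which 2 of the 4 values shown sit.

On these data alone, whether cyano and pyrrolidin-1-yl differ at all in this read-out on the shared core remains open.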